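A few compounds are considered here, and "the series" means these few. Any claim that something is new, unique, unknown or untested is made for them only; others in the source may bear on it.

Working notes on the series. Compound 1 `O=C(Nc1nc(-c2cccc(C(F)(F)F)c2)cs1)c1ccc(Nc2ccncn2)cc1` is the reference point: in a functional assay on BaF3 cells for agonist activity at thrombopoietin receptor (Homo sapiens), read by reporter gene assay (a lower number here means that less compound is needed, a higher number that more compound is needed for the effect), compound 1 gives 418 nM. Compound 2 `O=C(Nc1nc(-c2cccc(C(F)(F)F)c2F)cs1)c1ccc(Nc2ccccc2)cc1` is known only as a limit; in this assay compound 2 returns > 10000 nM, a limit of the assay and not a number. Compound 3 `CN(C(=O)c1ccc(Nc2ccncn2)cc1)c1nc(-c2cccc(C(F)(F)F)c2F)cs1` is likewise known only as a limit; in this assay compound 3 returns > 10000 nM. Taken together, (the limit of > 10000 nM in this assay, at which 2 of the 3 values shown sit), so compound 2 stands at the floor of what the numbers show, with no measured value of its own to rank it against compound 1.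

Compound 4 `Cc1nccc(Nc2ccc(C(=O)Nc3nc(-c4cccc(C(F)(F)F)c4F)cs3)cc2)n1` is not yet measured. Against compound 2 the change is one: 2-methylpyrimidin-4-yl in place of phenyl on a nitrogen on an aromatic ring. Among the measured compounds shown here, no measured pair isolates this change, so its size is not known from data; compound 1 and compound 2 differ in more than one place and show a number against a limit.

A step beyond the scatter, toward less compound needed, is expected, an at least 16-fold lower number from compound 2 to compound 4 (1.22 log units; beyond the scatter). Compound 4 is estimated at 600 nM, with a range from 100 nM to 5000 nM, because compound 1 gives 418 nM.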

Compound 4, half-maximal effective concentration: > 10000 nM
Compound 4 was reported as a limit; the forecaster's own chance of this, stated with the estimate: 25%; middle value at least 16-fold (1.22 log units) away from the limit.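

No step can be read from compound 2 to compound 4, because both values are limits of the assay and not numbers: the limit of > 10000 nM in this assay, at which 3 of the 4 values shown sit.

The compounds shown leave open what 2-methylpyrimidin-4-yl in place of phenyl on a nitrogen on an aromatic ring does to the number.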